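Working notes: from compound 2 to compound 3

The source may report more compounds than this note shows. Statements on the series, on what has been measured and on what is new or still open speak of the compounds shown alone.

Measured so far in a functional assay on U-937 cells (Homo sapiens), read by cAMP accumulation (a higher number here means that more compound is needed for the effect, a lower number that less compound is needed), as half-maximal effective concentration
- compound 1 `CCc1nn(C2CCCC2)c2c1CCN(c1ccccc1)C2=O` at 70 nM
- compound 2 `CCc1nn(-c2ccc(F)cc2)c2c1CCN(c1ccccc1OC)C2=O` at 3210 nM

Compound 2 stands at the higher of the two numbers, and its gap to compound 1 lies beyond the usual scatter. These two compounds differ in more than one place, so that gap cannot be assigned to any single change.

Compound 3 `CCc1nn(-c2ccc(F)cc2)c2c1CCN(c1cccc(C)c1)C2=O` has not yet been measured. It departs from compound 2 in one place, with 3-methylphenyl in place of 2-methoxyphenyl on an amide-type nitrogen in a ring. Going by the values given here, no measured pair isolates this change, so the expectation rests on little. A moderate fall in this assay is expected because compound 2 at 3210 nM sits high against compound 1 at 70 nM on the shared core, although a result within the scatter would remain possible. The estimated change is a 3.6-fold lower number from compound 2 to compound 3 (0.55 log units; beyond the scatter) and is expected to carry wide uncertainty. For compound 3 the estimate is 900 nM with an expected range of 180 nM to 4500 nM at this stage.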

Compound 3, half-maximal effective concentration: 780 nM
Beside the measured number, compound 3's estimate is 1.2-fold (0.06 log units) above it; measured number inside the range.
By their numbers in this assay, from the lowest: compound 1; then compound 3; then compound 2.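

In this assay, going by these compounds alone, the exchange of 2-methoxyphenyl for 3-methylphenyl on the amide-type nitrogen in a ring gives a 4.1-fold lower number from compound 2 to compound 3 (0.61 log units; beyond the scatter) and provides the only single-place comparison so far. The group at this position therefore affects the number while the rest of compound 2 stays fixed, and the step lies beyond the scatter. This single step cannot separate the removal of the methoxy group from the addition of the methyl group, or either of these from the different substitution position on the phenyl ring, and no supporting measurement explains the result.

Compound 1 differs from compound 3 in more than one place, so the gap between their numbers still cannot be assigned to any single change. Going by these compounds, it also remains open how the number would respond, with the rest of compound 3 unchanged, to a 3-aminophenyl group, a 3-carboxyphenyl group or a longer chain in place of the methyl group.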